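Moving the hydroxy group on compound 1

The source may report more compounds than this note shows. Statements on the series, on what has been measured and on what is new or still open speak of the compounds shown alone.

Measured in a functional assay on HCT-15 cells (Homo sapiens) for cytotoxicity, read by ELISA, with a stated time of 2 days; on this read-out lower numbers stand for stronger inhibition and higher numbers for weaker inhibition
compound 1 `Oc1cccc(-c2cc(-c3ccccc3)cc(-c3ccccc3)n2)c1` gives 9950 nM
compound 2 `Oc1cccc(-c2cc(-c3ccccc3)cc(-c3ccncc3)n2)c1` gives 27400 nM
compound 3 `Oc1cccc(-c2cc(-c3ccccc3)cc(-c3cccc(O)c3)n2)c1` gives 18400 nM

Compound 1 stands within the scatter of compound 3, and only compound 2 lies clearly apart (a 2.8-fold higher number from compound 1 to compound 2 (0.44 log units; beyond the scatter)). Compound 4 `Oc1ccc(-c2cc(-c3ccccc3)cc(-c3ccccc3)n2)cc1` differs from compound 1 in one place, next to the ring nitrogen (4-hydroxyphenyl in place of 3-hydroxyphenyl on an aromatic carbon). Within the data shown here, no measured step moves a hydroxy group. The nearest guide is a step that adds one, and it stays within the scatter (a 1.8-fold higher number from compound 1 to compound 3 (0.27 log units; within the scatter)). The pyridin-4-yl exchange (a 1.5-fold lower number from compound 2 to compound 3 (0.17 log units; within the scatter)) bears on it only loosely. In this assay no step beyond the scatter is therefore expected (a 1.1-fold higher number from compound 1 to compound 4 (0.04 log units; within the scatter)). For compound 4 the estimated value is 11000 nM (expected range 4500 nM to 25000 nM).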

Compound 4, half-maximal inhibitory concentration: 3700 nM
Beside the measured number, compound 4's estimate is 3.0-fold (0.47 log units) above it, outside the stated range (below it).
By their numbers in this assay, from the lowest: compound 4; then compounds 1, 3 and 2 (each within the scatter of the next, the first and the last beyond it).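

In this assay, this position responds to where the hydroxy sits on the phenyl group next to the ring nitrogen: 4-hydroxyphenyl in place of 3-hydroxyphenyl gives a 2.7-fold lower number from compound 1 to compound 4 (0.43 log units; beyond the scatter). The two groups share the same atoms and counts, so a change in attachment alone moves the number beyond the scatter, which adding a hydroxy to compound 1 did not do. Nothing available explains this difference. As far as these compounds go, it remains open whether an amine or a methoxy group in place of that hydroxy would hold the lower number, and whether the pyridin-4-yl exchange would act on compound 4 as it did on compound 1.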